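Swapping the Chlorophenyl Arm for an Oxane Arm

A few compounds are considered here, and "the series" means these few. Any claim that something is new, unique, unknown or untested is made for them only; others in the source may bear on it.

Compound 2 `C[C@@H](Nc1c(C(N)=O)cnc2ccc(-c3cccnc3)cc12)c1ccc(Cl)cc1` gives 109 nM in an assay on HT-29 cells for inhibition of Serine-protein kinase ATM (Homo sapiens), read by fluorescence, with a stated time of 1 h (a lower number here means a stronger inhibitor, a higher number a weaker inhibitor), and stands lowest of the two numbers shown. Compound 1 `C[C@@H](Nc1c(C(N)=O)cnc2ccc(C#N)cc12)c1ccc(Cl)cc1` gives 14400 nM in this assay, and the change is a 130-fold lower number from compound 1 to compound 2 (2.12 log units; beyond the scatter). Compound 3 `CNC(=O)c1cnc2ccc(-c3cccnc3)cc2c1N[C@H](C)c1ccc(Cl)cc1` reaches only the limit > 30000 nM in this assay; this is the limit of > 30000 nM in this assay, at which 1 of the 3 values shown sits. From compound 2 to compound 3 the step is an at least 270-fold higher number from compound 2 to compound 3 (2.43 log units; beyond the scatter). Compound 4 `C[C@H](Nc1c(C(N)=O)cnc2ccc(-c3cccnc3)cc12)C1CCOCC1` differs from compound 2 in 1-(oxan-4-yl)ethyl in place of 1-(4-chlorophenyl)ethyl on a nitrogen on an aromatic ring. Neither measured step touches this nitrogen substituent, so they bear on the new change only as a sign that single alterations to this core have moved the number by large amounts. Compound 4 is therefore expected to give a weaker number, with the step of a 5.5-fold higher number from compound 2 to compound 4 (0.74 log units; beyond the scatter), and its value in this assay is estimated at 600 nM, within 80 nM to 5000 nM.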

Compound 4, half-maximal inhibitory concentration: 168 nM
Compound 4: middle estimate off by 3.6-fold (0.55 log units), on the high side; the measured number falls inside the stated range.
By their numbers in this assay, from the lowest: compounds 2 and 4 (each within the scatter of the next); then compound 1. At a limit, above all of these: compound 3.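

In this assay, 1-(oxan-4-yl)ethyl can take the place of 1-(4-chlorophenyl)ethyl on this nitrogen with a 1.5-fold higher number from compound 2 to compound 4 (0.19 log units; within the scatter), so the two groups cannot be told apart here. Unlike the two earlier changes elsewhere on the core, this one leaves the number within the scatter, and the six-membered aromatic ring of carbon proves unnecessary at this place. Nothing measured here explains why the two groups read alike.

The compounds shown leave open how this nitrogen would respond to a group such as an aminoethyl chain or a carboxylic acid. They also leave open whether 1-(oxan-4-yl)ethyl would match 1-(4-chlorophenyl)ethyl with cyano in place of pyridin-3-yl.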